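Fluoro on the pendant phenyl of the shared core

The compounds below may be only part of what the source reports. "The series", "measured", "known", "first", "only" and "open" are said of these compounds alone.

In an ADME assay for permeability, using PAMPA, with a stated time of 30 min, at pH 7.4 (a higher number here means that the compound crosses the layer faster, a lower number that the compound crosses the layer more slowly), compound 2 `c1ccc(-c2ccc3c(NCCCNCc4ccco4)ccnc3c2)cc1` gives 237 10^-6 cm/s. For the measured compounds named here, compound 1 `COc1ccccc1Oc1ccc2c(NCCCNCc3ccco3)ccnc2c1` gives 317 10^-6 cm/s in this assay, and the only measured step, a 1.3-fold lower number from compound 1 to compound 2 (0.13 log units; within the scatter), keeps the two within the scatter. Compound 3 `Fc1ccc(-c2ccc3c(NCCCNCc4ccco4)ccnc3c2)cc1` differs from compound 2 by fluoro in place of hydrogen on an aromatic carbon. Going by the values given here, no measured step involves this kind of change, and the one step available is small, so no shift beyond the scatter is expected in this assay. Compound 3 is therefore estimated at 230 10^-6 cm/s, with a range of 130 10^-6 cm/s to 400 10^-6 cm/s. The expected step is a 1.0-fold lower number from compound 2 to compound 3 (0.01 log units; within the scatter), inside the scatter.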

Compound 3, apparent permeability: 237 10^-6 cm/s
Compound 3: the middle estimate sits 1.0-fold (0.01 log units) below what was measured, and the stated range covers the measured number.
By their numbers in this assay, from the lowest: compounds 2, 3 and 1 (each within the scatter of the next).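

In this assay, for the compounds shown here, fluoro para to a large group gives no change at the digits printed from compound 2 to compound 3 (within the scatter), the first reading of this change on the shared core. Exchanging 2-methoxyphenoxy for 4-fluorophenyl gives a 1.3-fold lower number from compound 1 to compound 3 (0.13 log units; within the scatter), so this exchange also stays within the scatter. No supporting data bear on this result.

As far as these compounds go, whether an amine or a carboxylic acid at this place would give a step beyond the scatter remains open. Also open is how the read-out responds to a longer chain on the shared core, since all changes shown lie on the aromatic substituent.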